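This account rests on a few compounds, and the source may have more. Where it says the series, first, only, none or still open, it means among the compounds named here.

Among the measured compounds shown here, compound 2, `Cc1csc(NC(=O)Cn2cc(-c3ccc(F)cc3)nn2)n1`, is the one compound with an actual number in a functional assay on BMDM cells (Mus musculus, strain C57BL/6) for inhibition, with a stated time of 2 days; on this read-out higher numbers stand for weaker inhibition and lower numbers for stronger inhibition: compound 2 gives 250 nM. Compound 1, `COC(=O)c1ccc(-c2cn(CC(=O)Nc3nc(C)cs3)nn2)cc1`, is reported in this assay only as a limit, > 30000 nM. For the measured compounds named here, the single measured step, an at least 120-fold lower number from compound 1 to compound 2 (2.07 log units; beyond the scatter), rests on the limit of > 30000 nM in this assay, at which 1 of the 2 values shown sits, and shows that fluoro in place of methoxycarbonyl on the aromatic carbon moved the read-out strongly toward stronger inhibition. Compound 3, `Cc1csc(NC(=O)Cn2cc(-c3ccc(C(=O)O)cc3)nn2)n1`, differs from compound 2 by carboxy in place of fluoro on an aromatic carbon. Going by the values given here, this change reverses the sense of the one measured step: a carbonyl-bearing group returns to the aromatic carbon where compound 1 carried methoxycarbonyl, and the read-out of compound 1 was a limit. Carboxy is not methoxycarbonyl, so the size of the return cannot be taken from the measured step directly, but a large step toward weaker inhibition is expected, a 40-fold higher number from compound 2 to compound 3 (1.60 log units; beyond the scatter). Compound 3 is therefore estimated at about 10000 nM in this assay, with a range from 1500 nM to 30000 nM, and a substantial chance that only a limit is reported.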

Compound 3, half-maximal inhibitory concentration: > 30000 nM
Compound 3 gave a limit, no number (the forecaster's own chance of this, stated with the estimate: 45%); at least 3.0-fold (0.47 log units) between middle value and limit.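

In this assay, carboxy in place of fluoro on the aromatic carbon para to a large group gives an at least 120-fold higher number from compound 2 to compound 3 (2.07 log units; beyond the scatter). Together with the earlier step, this shows that the loss at this position is not confined to methoxycarbonyl: of the three compounds shown, both that carry a carbonyl-bearing group here read at the limit, and only compound 2, with fluoro, gives an actual number. The step from compound 1 to compound 3 cannot be read, so the compounds give no order between methoxycarbonyl and carboxy, and the methyl on the oxygen shows no readable effect: the limit of > 30000 nM in this assay, at which 2 of the 3 values shown sit.

The compounds shown leave open whether the read-out follows the carbonyl-bearing groups as a class or depends on fluoro itself, a question that a nitrile, a primary amide, an amine or chloro on the same aromatic carbon would address. They also leave open how the unsubstituted hydrogen at this position compares with fluoro, and so whether fluoro adds to inhibition or the two larger groups simply take it away.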